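Working notes: phenyl in place of cyclopropyl

The source may hold more compounds than are shown below. What is called first, only, known or untested is meant among the compounds shown, and "the series" means these compounds.

Measured so far in an ADME assay on CEMx174 cells (Homo sapiens) for cytotoxicity; on this read-out lower numbers stand for higher toxicity in this test and higher numbers for lower toxicity in this test:
- Compound 1 (`CC1=C(C(=O)OCC2CCCCC2)C(c2cccc(O)c2)NC(=S)N1`) gives > 10000 nM as a limit.
- Compound 2 (`CCC1=C(C(=O)OCC2CCCCC2)C(c2cccc(O)c2)NC(=O)N1`) gives > 10000 nM as a limit.
- Compound 3 (`O=C1NC(C2CC2)=C(C(=O)OCC2CCCCC2)C(c2cccc(O)c2)N1`) gives > 10000 nM as a limit.

Compound 3 stands at > 10000 nM as a limit and not as a number. Among the compounds with values here, the series so far shows the limit of > 10000 nM in this assay, at which 3 of the 3 values shown sit, and offers no number by which to rank the compounds.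

The change to compound 4 (`O=C1NC(c2ccccc2)=C(C(=O)OCC2CCCCC2)C(c2cccc(O)c2)N1`) is phenyl in place of cyclopropyl on a double-bonded ring carbon and amounts to phenyl in place of cyclopropyl on a double-bonded ring carbon. Within the data shown here, one measured step bears on it, also on a double-bonded ring carbon: a step that the two limits leave unreadable from compound 2 to compound 3 and so it has no size to carry over. Among the measured compounds shown here, no measured step has phenyl at this place, which leaves the forecast weak.

The expectation rests on the limit of > 10000 nM in this assay, at which 3 of the 3 values shown sit, and on nothing finer. In this assay no step beyond the scatter is expected, neither direction is favoured, and compound 4 will most likely be reported as a limit again. The expected change is a step that the limit leaves unreadable from compound 3 to compound 4 as an estimate only. For compound 4 the estimated value is 12000 nM with an expected range from 5000 nM to 40000 nM on this reading.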

Compound 4, half-maximal cytotoxic concentration: > 10000 nM
Compound 4 was reported as a limit; the forecaster's own chance of this, stated with the estimate: 80%; the middle value does not contradict the limit.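

In this assay compound 4 gives > 10000 nM, a limit and not a number. No new step can be read from compound 2 or compound 3 to compound 4, and nothing ranks the series: the limit of > 10000 nM in this assay, at which 4 of the 4 values shown sit. The compounds shown leave open whether any change on the shared core would give a numerical value in this assay.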